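Chloro for fluoro on the aryl of compound 1

The compounds below may be only part of what the source reports. "The series", "measured", "known", "first", "only" and "open" are said of these compounds alone.

Compound 1, `Cc1nn(C)c(Oc2ccc(OC(F)(F)F)cc2)c1/C=N\OCc1c(Cl)c(-c2ccc(F)cc2)nn1C`, gives 2970 nM in a functional assay on SGC-7901 cells (Homo sapiens) for antiproliferative activity, read by MTT assay, with a stated time of 72 h (a higher number here means a weaker inhibitor, a lower number a stronger inhibitor), the lowest of the two numbers to hand. Compound 2, `Cc1nn(C)c(Oc2ccc(F)cc2)c1/C=N\OCc1c(Cl)c(-c2ccc(Cl)cc2)nn1C`, gives 4430 nM in this assay; the two values lie within the scatter of each other, so no order between compound 1 and compound 2 is read from them. Compound 3, `Cc1nn(C)c(Oc2ccc(OC(F)(F)F)cc2)c1/C=N\OCc1c(Cl)c(-c2ccc(Cl)cc2)nn1C`, is not yet measured. It differs from compound 1 by chloro in place of fluoro on an aromatic carbon, para to a large group; cut one bond further out, 4-fluorophenyl becomes 4-chlorophenyl. Among the measured compounds shown here, no pair of measured compounds isolates this change; compound 2 carries chloro at that position but differs from compound 1 elsewhere as well, so its value alone cannot separate the two changes. The step from compound 1 to compound 3 is expected to be a 1.2-fold higher number from compound 1 to compound 3 (0.07 log units; within the scatter), not beyond the scatter in either direction. Compound 3 is expected to give 3500 nM in this assay, between 1500 nM and 8000 nM.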

Compound 3, half-maximal inhibitory concentration: 3220 nM
For compound 3 the middle estimate is 1.1-fold (0.04 log units) above the measured one; the range from low to high includes it.
By their numbers in this assay, from the lowest: compounds 1, 3 and 2 (each within the scatter of the next).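

In this assay, the change from 4-fluorophenyl to 4-chlorophenyl now stands alone, and the result is a 1.1-fold higher number from compound 1 to compound 3 (0.04 log units; within the scatter); fluoro and chloro at this position are therefore not told apart with trifluoromethoxy on the other aryl. The same compound also isolates a second change, with the 4-chlorophenyl held constant, giving a 1.4-fold lower number from compound 2 to compound 3 (0.14 log units; within the scatter), so trifluoromethoxy and fluoro cannot be ordered in this setting either. No measurement to hand speaks to the origin of these values.

From the compounds shown here alone, whether the chloro-for-fluoro step stays the same with fluoro in place of trifluoromethoxy remains open. Also open is how an amine or a carboxylic acid on the same aromatic carbon would read, since chloro and fluoro are the only groups shown there.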